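The source may hold more compounds than are shown below. What is called first, only, known or untested is meant among the compounds shown, and "the series" means these compounds.

Compound 1 `COc1cc(C(=O)N(C)C)nn1-c1ccccc1` and compound 2 `COc1cc(C(=O)NC(C)C)nn1-c1ccccc1` share one core and differ only at the amide. In a functional assay on the whole organism (strain Wistar) for inhibition, with Rattus norvegicus as the target, read by paw edema, with stated times of 30 min and 3 h, at a dose of 100 mg/kg by the oral route (a lower number here means less inhibition, a higher number more inhibition at the dose given (going by the name of the read-out)), compound 1 gives 47.5%, whereas compound 2 gives 24.8%, the lower of the two numbers, and the fall a number 22.7 percentage points lower from compound 1 to compound 2 (beyond the scatter) lies beyond the scatter. Compound 3 `COc1cc(C(=O)N2CCCCC2)nn1-c1ccccc1` carries piperidin-1-yl in place of isopropylamino on a carbonyl carbon. Within the data shown here, the single step that bears on this change is a number 22.7 percentage points lower from compound 1 to compound 2 (beyond the scatter), a modest fall when the dimethylamino group was exchanged for one bearing a donor; since compound 3 returns to a group with no donor, a rise back toward compound 1 is expected, a number 15.2 percentage points higher from compound 2 to compound 3 (beyond the scatter). Compound 3 is thus estimated at 40%, expected to lie between 25% and 55%.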

Compound 3, a percentage reported as inhibition, in the whole organism at one dose (the size of the read-out at that dose, not a potency): 28.2%
Beside the measured number, compound 3's estimate is 11.8 percentage points above it; the range from low to high includes it.
By their numbers in this assay, from the lowest: compounds 2 and 3 (each within the scatter of the next); then compound 1.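

In this assay, piperidin-1-yl in place of isopropylamino on a carbonyl carbon gives a number 3.4 percentage points higher from compound 2 to compound 3 (within the scatter) and so the loss of the hydrogen-bond donor does not by itself separate these two amides. Piperidin-1-yl in place of dimethylamino gives a number 19.3 percentage points lower from compound 1 to compound 3 (beyond the scatter) and this leaves compound 1 alone among the three compounds at this position. Nothing measured here gives a reason for this. Going by these compounds, whether morpholin-4-yl, a primary amide or a carboxylic acid at this carbonyl carbon would stand with compound 1 or with compounds 2 and 3 remains open.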